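The compounds below may be only part of what the source reports. "The series", "measured", "known", "first", "only" and "open" are said of these compounds alone.

Compound 1 `COc1cccc(C(c2c[nH]c3ccc(Br)cc23)c2c[nH]c3ccc(Br)cc23)c1OC`: 89000 nM
Compound 2 `Brc1ccc(C(c2c[nH]c3ccc(Br)cc23)c2c[nH]c3ccc(Br)cc23)cc1`: 3200 nM

In a functional assay on MCF7 cells (Homo sapiens) for inhibition, read by MTT assay, with a stated time of 48 h (on this read-out lower numbers stand for stronger inhibition and higher numbers for weaker inhibition), compound 2 has the lower of the two numbers at 3200 nM, while compound 1 gives 89000 nM. Compound 3 `CCCCCCCC(c1c[nH]c2ccc(Br)cc12)c1c[nH]c2ccc(Br)cc12` keeps the shared core and puts heptyl in place of 4-bromophenyl on a saturated chain carbon bound to two aromatic carbons. Among the compounds with values here, only one measured step bears on this change, a 28-fold lower number from compound 1 to compound 2 (1.44 log units; beyond the scatter), which is large and beyond the scatter. Within the data shown here, it shows that the group at this place can matter, yet both of its compounds carry a ring there, so no measured compound shows what a chain does. A moderately higher number is therefore expected, with wide uncertainty, and the expected step is a 2.5-fold higher number from compound 2 to compound 3 (0.40 log units; beyond the scatter). For compound 3 the estimated value is 8000 nM, with an expected range of 1500 nM to 40000 nM.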

Compound 3, half-maximal inhibitory concentration: 5500 nM
Compound 3: the middle estimate sits 1.5-fold (0.16 log units) above what was measured; the measured number falls inside the stated range.
By their numbers in this assay, from the lowest: compounds 2 and 3 (each within the scatter of the next); then compound 1.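

In this assay, a ring is not required at this position for a number in this range: with heptyl, an open chain, on a saturated chain carbon bound to two aromatic carbons, the step is a 1.7-fold higher number from compound 2 to compound 3 (0.24 log units; within the scatter), so the chain and 4-bromophenyl cannot be told apart here. The other step, a 16-fold lower number from compound 1 to compound 3 (1.21 log units; beyond the scatter), shows that two quite different groups both give much lower numbers than 2,3-dimethoxyphenyl. Nothing measured here explains why these groups compare as they do.

The compounds shown leave open how the number would respond to a shorter or longer chain, or to an amine or a carboxylic acid at the end of the chain. They also leave open whether plain phenyl would match 4-bromophenyl.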